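Aryl-swap on the shared core: cytotoxicity in NCI-H1975 cells

A few compounds are considered here, and "the series" means these few. Any claim that something is new, unique, unknown or untested is made for them only; others in the source may bear on it.

Measured so far:
compound 1 `C=CCn1c(=O)/c(=C\c2cccc(C)c2)[nH]c(=O)/c1=C\c1ccccc1OC` — 32800 nM
compound 2 `C=CCn1c(=O)/c(=C\c2cccc(F)c2)[nH]c(=O)/c1=C\c1ccccc1OC` — 25600 nM

In a functional assay on NCI-H1975 cells (Homo sapiens) for cytotoxicity, read by CCK-8 assay, with a stated time of 72 h (on this read-out lower numbers stand for stronger inhibition and higher numbers for weaker inhibition), compound 1 gives the highest of the two numbers; compound 2 is nearest, and the step of a 1.3-fold lower number from compound 1 to compound 2 (0.11 log units; within the scatter) lies within the scatter, so the two values show no order. Compound 3 `C=CCn1c(=O)/c(=C\c2ccccc2C(F)(F)F)[nH]c(=O)/c1=C\c1ccccc1OC` differs from compound 1 by 2-(trifluoromethyl)phenyl in place of 3-methylphenyl on a double-bonded chain carbon bound to an aromatic carbon. For the measured compounds named here, the only measured step, fluoro in place of methyl on an aromatic carbon, is a different change and bears on this one only loosely; it gave no shift beyond the scatter. For compound 3 the expected step is therefore a 1.1-fold lower number from compound 1 to compound 3 (0.04 log units; within the scatter), none beyond the scatter. Compound 3 is estimated at 30000 nM in this assay, within 10000 nM to 90000 nM.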

Compound 3, half-maximal inhibitory concentration: 14500 nM
Compound 3: the middle estimate sits 2.1-fold (0.32 log units) above what was measured; the measured number falls inside the stated range.
By their numbers in this assay, from the lowest: compounds 3, 2 and 1 (each within the scatter of the next, the first and the last beyond it).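

At the double-bonded chain carbon bound to an aromatic carbon, 2-(trifluoromethyl)phenyl in place of 3-methylphenyl gives a step beyond the scatter in this assay (a 2.3-fold lower number from compound 1 to compound 3 (0.35 log units; beyond the scatter)), while in place of 3-fluorophenyl the step stays within it (a 1.8-fold lower number from compound 2 to compound 3 (0.25 log units; within the scatter)). This position therefore responds modestly to the aryl group, with compound 3 separated only from compound 1. No available evidence accounts for this step.

The compounds shown do not separate the trifluoromethyl group itself from its place on the phenyl ring. As far as these compounds go, how a phenyl group carrying an amine or a carboxylic acid would read here also remains open.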